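Removing a Methyl from the Core of Compound 1

The source may hold more compounds than are shown below. What is called first, only, known or untested is meant among the compounds shown, and "the series" means these compounds.

Measured in a functional assay on OVCAR-3 cells (Homo sapiens); on this read-out higher numbers stand for weaker inhibition of growth and lower numbers for stronger inhibition of growth:
compound 1, `COc1ccc(-c2cc(O)c3c(C)cc(C)nc3n2)cc1`, 32400 nM
compound 2, `COc1ccccc1-c1cc(O)c2cccnc2n1`, 47900 nM
compound 3, `COc1ccccc1-c1cc(O)c2c(C)ccnc2n1`, 12900 nM

Compound 2 and compound 3 share one core and differ in a single place: hydrogen in place of methyl on an aromatic carbon. In this assay that change gave a 3.7-fold higher number from compound 3 to compound 2 (0.57 log units; beyond the scatter). Compound 1 is built on another core; how the two cores differ is not broken down here. Compound 4, `COc1ccc(-c2cc(O)c3ccc(C)nc3n2)cc1`, arises from compound 1 by the same kind of change, (hydrogen in place of methyl on an aromatic carbon), though not the same one: in compound 1 the place is also meta to a methyl group (1 heavy atom). Because a 3.7-fold higher number from compound 3 to compound 2 (0.57 log units; beyond the scatter), a step of similar size is expected here, a 3.1-fold higher number from compound 1 to compound 4 (0.49 log units; beyond the scatter), resting on that single measured pair. Compound 4 is therefore estimated at 100000 nM, expected to fall between 35000 nM and 280000 nM.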

Compound 4, concentration for 50% growth inhibition: > 100000 nM
Compound 4: a limit, no number; the forecaster's own chance of this, stated with the estimate: 25%; the middle value sits exactly at the limit.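

In this assay compound 4 gives > 100000 nM, which is a limit of the assay and not a number. Replacing the methyl with hydrogen on this core gives an at least 3.0-fold higher number from compound 1 to compound 4 (0.48 log units; beyond the scatter). In both pairs shown, the change weakens growth inhibition, but two pairs make no general rule, and the true size of the second step stays unknown, so it cannot be said whether the step carries over unchanged in size: the same change on two cores in this assay, a 3.7-fold higher number (0.57 log units; beyond the scatter) from compound 3 to compound 2 and an at least 3.0-fold higher number (0.48 log units; beyond the scatter) from compound 1 to compound 4; the limit leaves it open whether they differ.

The compounds shown leave open what other groups would do at this place on the ring. An ethyl group, a chlorine atom or an amine in place of the methyl could each give a different result.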